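Working notes on the step from compound 1 to compound 3

The source may hold more compounds than are shown below. What is called first, only, known or untested is meant among the compounds shown, and "the series" means these compounds.

Compound 1 `COc1ccc(C2SCC(=O)N2CCN2CCCCC2)cc1`: 100%
Compound 2 `O=C1CSC(c2cccc(Cl)c2)N1CCN1CCCCC1`: 100%

In an ADME assay on Vero cells (Chlorocebus sabaeus) for cytotoxicity, read by neutral red uptake, tested at 25 ug/mL (on this read-out higher numbers stand for a weaker effect at the one concentration tested and lower numbers for a stronger effect), compound 1 gives 100% and compound 2 gives 100%; compound 1 stands level with compound 2 at the digits shown, the two values within the scatter of each other. Compound 3 `O=C1CSC(c2ccc(F)cc2)N1CCN1CCCCC1` has not yet been measured in this assay. It differs from compound 1 by fluoro in place of methoxy on an aromatic carbon. Going by the values given here, no measured step covers this change, so the expectation rests on the pair at hand: because compound 1 gives 100% and compound 2 gives 100%, the expected step is a number 2 percentage points lower from compound 1 to compound 3 (within the scatter), none beyond the scatter. Compound 3 is therefore estimated at 98% in this assay, in a range from 85% to 105%.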

Compound 3, a percentage reported as activity, at one concentration (the size of the read-out at that concentration, not a potency): 100%
Compound 3: middle estimate off by 2 percentage points, on the low side; the range from low to high includes it.
By their numbers in this assay, from the lowest: compounds 1, 2 and 3 (each within the scatter of the next).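

In this assay, fluoro in place of methoxy on an aromatic carbon, para to a large group, gives no change at the digits printed from compound 1 to compound 3 (within the scatter) and so leaves the read-out flat. 4-Fluorophenyl in place of 3-chlorophenyl on a saturated ring carbon likewise gives no change at the digits printed from compound 2 to compound 3 (within the scatter), so all three aryl variants shown stand level. No evidence on hand bears on this result.

Going by these compounds, whether an amine or a carboxylic acid on that aromatic ring would move the read-out remains open. So does the effect of any change elsewhere on the shared core.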